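The source may hold more compounds than are shown below. What is called first, only, known or untested is meant among the compounds shown, and "the series" means these compounds.

Compound 1 `N#C[C@@H]1CCCN1C(=O)[C@@H]1C[C@H](CO)CN1` gives 64% in an assay on the whole organism (plasma, strain Sprague-Dawley) for inhibition of Dipeptidyl peptidase 4 (Rattus norvegicus), with a stated time of 6 h, at a dose of 1 mg/kg by the oral route (on this read-out lower numbers stand for less inhibition and higher numbers for more inhibition at the one dose given (going by the name of the read-out)), and stands highest of the three numbers; compound 2 `N#C[C@@H]1CCCN1C(=O)[C@@H]1C[C@H](C(=O)N2CCCCCCC2)CN1` gives 63%, which lies within the scatter of compound 1, and compound 3 `N#C[C@@H]1CCCN1C(=O)[C@@H]1C[C@H](C(N)=O)CN1` gives 47%. Compound 4 `CN(C)C(=O)[C@@H]1CN[C@H](C(=O)N2CCC[C@H]2C#N)C1` awaits measurement; it differs from compound 1 by dimethylcarbamoyl in place of hydroxymethyl on a saturated ring carbon. Among the compounds with values here, two measured steps bear on this change: a number 17 percentage points lower from compound 1 to compound 3 (beyond the scatter), and a number 16 percentage points lower from compound 2 to compound 3 (beyond the scatter), which shows the unsubstituted amide of compound 3 sitting below the ring-substituted amide of compound 2. A nitrogen-substituted amide is therefore expected to fall less than compound 3 did, so the step of a number 7 percentage points lower from compound 1 to compound 4 (within the scatter) is expected to be small and downward, near the edge of the scatter. Compound 4 is estimated at 57%, within 45% to 69%.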

Compound 4, a percentage reported as inhibition, in the whole organism at one dose (the size of the read-out at that dose, not a potency): 76%
Estimate against measurement, compound 4: 19 percentage points below, and the stated range ends below it.
By their numbers in this assay, from the lowest: compound 3; then compounds 2 and 1 (each within the scatter of the next); then compound 4.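

In this assay the step of a number 29 percentage points higher from compound 3 to compound 4 (beyond the scatter) and the step of a number 13 percentage points higher from compound 2 to compound 4 (beyond the scatter) show that the group on the carbonyl carbon strongly shapes the read-out, with dimethylamino above both amino and the eight-membered ring group. The step of a number 12 percentage points higher from compound 1 to compound 4 (beyond the scatter) shows that an amide on this saturated ring carbon can exceed hydroxymethyl, which compound 2 and compound 3 did not show. No measurement at hand accounts for these steps.

On these data alone, how methylcarbamoyl, diethylcarbamoyl or a carboxylic acid would read on this ring carbon remains open.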